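The source may report more compounds than this note shows. Statements on the series, on what has been measured and on what is new or still open speak of the compounds shown alone.

Measured compounds in a functional assay on PANC-1 cells (Homo sapiens) for inhibition, read by MTT assay, with a stated time of 24 h, tested at 10 uM; on this read-out lower numbers stand for less inhibition and higher numbers for more inhibition at the one concentration tested (going by the name of the read-out):
- compound 1 `CC(C)=CCC/C(C)=C/CC1Cc2c(O)cc(=O)n(CCCO)c2CC1(C)C`: 0%
- compound 2 `CC(C)=CCC1Cc2c(OC(=O)Nc3ccc(Cl)c(Cl)c3)cc(=O)n(CCCO)c2CC1(C)C`: 1.8%
- compound 3 `CC(C)=CCC/C(C)=C/CC1Cc2c(OC(=O)Nc3cccc(F)c3)cc(=O)n(CCCO)c2CC1(C)C`: 0%

Compound 3 stands level with compound 1 at the digits printed; together the two are the lowest of the three numbers. Its nearest neighbour on the numbers is compound 1, with no change within the scatter, and its furthest is compound 2, which lies a little higher but still within the scatter. Within the data shown here, the one measured step that leads into the series, no change at the digits printed from compound 1 to compound 3 (within the scatter), shows that adding the (3-fluorophenyl)carbamoyl group to the oxygen on the aromatic ring of the shared core left the read-out unchanged.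

Compound 4 `CC(C)=CCC/C(C)=C/CC1Cc2c(OC(=O)Nc3ccc(Cl)c(Cl)c3)cc(=O)n(CCCO)c2CC1(C)C` differs from compound 3 in a single place: 3,4-dichlorophenyl in place of 3-fluorophenyl on an amide-type nitrogen. Among the measured compounds shown here, no measured step covers this exchange directly. Compound 2 carries the same 3,4-dichlorophenyl carbamate on a core that otherwise differs from compound 4, and its value and that of compound 3 sit within the scatter of each other. Nothing in the three numbers, all close to the bottom of the read-out, points to a shift beyond the scatter in this assay for this step.

Compound 4 is therefore expected to give 2% in this assay, with a range of 0% to 12%, a step of a number 2 percentage points higher from compound 3 to compound 4 (within the scatter) that is estimated to stay within the scatter.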

Compound 4, a percentage reported as inhibition, at one concentration (the size of the read-out at that concentration, not a potency): 0%
The estimate for compound 4 lay 2 percentage points above the measured number; low and high end bracket the measured number.
By their numbers in this assay, from the lowest: compounds 1, 3, 4 and 2 (each within the scatter of the next).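

In this assay, the exchange of 3-fluorophenyl for 3,4-dichlorophenyl on the amide-type nitrogen gives no change at the digits printed from compound 3 to compound 4 (within the scatter), so this position now has two halogenated phenyl groups that the read-out does not separate. Placing (3,4-dichlorophenyl)carbamoyl in place of hydrogen on the oxygen on the aromatic ring gives no change at the digits printed from compound 1 to compound 4 (within the scatter), which shows that a second carbamate on this oxygen also leaves the read-out within the scatter of the core of compound 1. With the 3,4-dichlorophenyl carbamate held constant, 3-methylbut-2-en-1-yl in place of hydrogen on a saturated chain carbon bound to a double-bonded chain carbon gives a number 1.8 percentage points lower from compound 2 to compound 4 (within the scatter), so this change in the chain is also not separated by the read-out.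

Whether an amine or a carboxylic acid on the phenyl ring of the carbamate would move the read-out beyond the scatter remains open, since the aryl groups shown carry only fluorine or chlorine. No supporting data bear on why these compounds read as they do.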